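The source may hold more compounds than are shown below. What is called first, only, known or untested is meant among the compounds shown, and "the series" means these compounds.

Compound 3 `COc1cc(CC(O)c2ccc(-c3ccc(F)cc3)cc2)c([N+](=O)[O-])cc1OC` is the only one of the three measured compounds that gives an actual number in an ADME assay on HeLa Rh cells (Homo sapiens) for cytotoxicity, read by microscopy (a higher number here means that more compound is tolerated, a lower number that less compound is tolerated), where compound 3 reaches 4500 nM. Compound 1 `COc1cc(CC(O)c2ccc(-c3ccc(C=O)cc3)cc2)c([N+](=O)[O-])cc1OC` reaches only the limit of this assay, > 245000 nM. Compound 2 `COc1cc(CC(O)c2ccc(-c3ccc(CO)cc3)cc2)c([N+](=O)[O-])cc1OC` likewise stops at the limit of this assay, > 244000 nM. Compound 4 `COc1cc(CC(O)c2ccc(-c3cccc(Cl)c3)cc2)c([N+](=O)[O-])cc1OC` differs from compound 3 by 3-chlorophenyl in place of 4-fluorophenyl on an aromatic carbon. Going by the values given here, the measured steps that lead to compound 3, an at least 54-fold lower number from compound 1 to compound 3 (1.73 log units; beyond the scatter) and an at least 54-fold lower number from compound 2 to compound 3 (1.73 log units; beyond the scatter), both exchange an oxygen-bearing group for a halogen, whereas the step to compound 4 swaps one halogen for another, and no measured step tests such a swap. The step to compound 4 is therefore expected to stay within the scatter, no change at the digits printed from compound 3 to compound 4 (within the scatter). Compound 4 is estimated at 4500 nM, between 1500 nM and 14000 nM.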

Compound 4, half-maximal cytotoxic concentration: 5900 nM
Estimate against measurement, compound 4: 1.3-fold (0.12 log units) below; the range from low to high includes it.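

In this assay, the aryl group at this position can carry a different halogen at a different ring position with no readable effect: a 1.3-fold higher number from compound 3 to compound 4 (0.12 log units; within the scatter). The much lower number of compound 3 is therefore not specific to 4-fluorophenyl: an at least 41-fold lower number from compound 2 to compound 4 (1.61 log units; beyond the scatter), and an at least 41-fold lower number from compound 1 to compound 4 (1.61 log units; beyond the scatter), with both steps starting from a limit of the assay rather than a number. As far as these compounds go, the halogen and its ring position changed together here, and the share of each stays open. Also open, from the compounds shown here alone, is whether an amine or a carboxylic acid on this ring would match compound 4 or compound 1.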